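The source may hold more compounds than are shown below. What is called first, only, known or untested is meant among the compounds shown, and "the series" means these compounds.

In an ADME assay on liver for metabolic stability, with Liver microsome (Homo sapiens) as the target, read by LC-MS, using microsomes (on this read-out higher numbers stand for fast clearance and lower numbers for slow clearance), compound 1 `O=C(NCc1cc(Cl)ccc1-n1cnnn1)[C@@H]1CCON1C(=O)[C@H](O)c1ccccc1` returns only a limit of the assay, < 12 mL.min-1.g-1. Compound 3 `O=C(NCc1cc(Cl)ccc1-n1cnnn1)[C@@H]1C[C@@H]2C[C@@H]2N1C(=O)[C@H](O)Cn1cccn1` likewise returns a limit, < 12 mL.min-1.g-1. Going by the values given here, compound 2 `CC1(C[C@@H](O)C(=O)N2C[C@H]3C[C@H]3[C@H]2C(=O)NCc2cc(Cl)ccc2-n2cnnn2)CC1` is the one member of the set with a number rather than a limit: in this assay compound 2 gives 12 mL.min-1.g-1, which rests at the limit of < 12 mL.min-1.g-1 in this assay, at which 2 of the 3 values shown sit, and so cannot be ordered against compound 1 or compound 3. Among the compounds with values here, no two measured compounds differ in a single place, so no measured step exists.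

Compound 4 `CC(C)(C)[C@@H](O)C(=O)N1C[C@H]2C[C@H]2[C@H]1C(=O)NCc1cc(Cl)ccc1-n1cnnn1` has not yet been measured. It differs from compound 2 in one place: tert-butyl in place of (1-methylcyclopropyl)methyl on a saturated chain carbon bound to a carbonyl carbon and an oxygen on a saturated carbon. The entering group is the smaller of the two and carries no ring. Within the data shown here, with no measured step to lean on, the expected step from compound 2 to compound 4, a 1.2-fold lower number from compound 2 to compound 4 (0.08 log units; within the scatter), is one that stays within the scatter in this assay. Compound 4 is therefore expected to give 10 mL.min-1.g-1, with a range of 5 mL.min-1.g-1 to 20 mL.min-1.g-1, and a fair chance that the assay once more reports only a limit.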

Compound 4, intrinsic clearance in microsomes: 22 mL.min-1.g-1
The estimate for compound 4 lay 2.2-fold (0.34 log units) below the measured number, and the stated range ends below it.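

Going by these compounds alone, replacing (1-methylcyclopropyl)methyl with tert-butyl on a saturated chain carbon bound to a carbonyl carbon and an oxygen on a saturated carbon provides the first measured step: in this assay, the change gives a 1.8-fold higher number from compound 2 to compound 4 (0.26 log units; within the scatter). As this step stays within the scatter, the read-out does not separate the two groups at this place, even though the entering group carries no ring. Compound 1 and compound 3 each return only a limit and remain outside this comparison: the limit of < 12 mL.min-1.g-1 in this assay, at which 2 of the 4 values shown sit.

From the compounds shown here alone, whether an amine, a carboxylic acid or a longer chain at this place would give a step beyond the scatter remains open. Also open, going by these compounds, is whether tert-butyl would read the same way on the core of compound 1 or the core of compound 3.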